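The compounds below may be only part of what the source reports. "The series", "measured", "known", "first", "only" and "open" are said of these compounds alone.

Of the compounds shown here, three sharing one core have been measured in a functional assay on T-24 cells (Homo sapiens) for antiproliferative activity, read by MTT assay, with a stated time of 48 h; on this read-out higher numbers stand for weaker inhibition and lower numbers for stronger inhibition. Compound 1 `CCOc1ccc(NC(=O)Nc2cccc(CNc3nccnc3Cl)c2)cc1` gives 9080 nM in this assay. Compound 2 `O=C(Nc1ccc(Cl)cc1)Nc1cccc(CNc2nccnc2Cl)c1` gives 5470 nM in this assay, and the step of a 1.7-fold lower number from compound 1 to compound 2 (0.22 log units; within the scatter) is within the scatter. Compound 3 `CN(C)c1ccc(NC(=O)Nc2cccc(CNc3nccnc3Cl)c2)cc1` gives 20200 nM in this assay, the highest of the three numbers; the steps of a 2.2-fold higher number from compound 1 to compound 3 (0.35 log units; beyond the scatter) and a 3.7-fold higher number from compound 2 to compound 3 (0.57 log units; beyond the scatter) are both modest and beyond the scatter, so compound 3 stands as the weakest of the set.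

Compound 4 `CS(=O)(=O)c1ccc(NC(=O)Nc2cccc(CNc3nccnc3Cl)c2)cc1` has not yet been measured. It differs from compound 3 by methylsulfonyl in place of dimethylamino on an aromatic carbon, on an aromatic carbon of a six-membered aromatic ring of carbon only, para to a large group. Among the measured compounds shown here, the only steps that bear on this change are those into compound 3, where dimethylamino gave higher numbers than ethoxy or chloro; nothing measured holds a methylsulfonyl group, so the size of its effect is uncertain. Since the dimethylamino group is removed, a lower number is expected for compound 4 than for compound 3, with a 2.5-fold lower number from compound 3 to compound 4 (0.40 log units; beyond the scatter) the expected step. Compound 4 is thus estimated at 8000 nM in this assay, within 3000 nM to 25000 nM.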

Compound 4, half-maximal inhibitory concentration: 29300 nM
For compound 4 the middle estimate is 3.7-fold (0.56 log units) below the measured one; measured number outside the range, above it.
By their numbers in this assay, from the lowest: compounds 2 and 1 (each within the scatter of the next); then compounds 3 and 4 (each within the scatter of the next).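

In this assay, methylsulfonyl in place of dimethylamino, on an aromatic carbon para to a large group, gives no change that can be told from the scatter, with a 1.5-fold higher number from compound 3 to compound 4 (0.16 log units; within the scatter) as the step. Against the other two groups the picture differs, with a 5.4-fold higher number from compound 2 to compound 4 (0.73 log units; beyond the scatter) and a 3.2-fold higher number from compound 1 to compound 4 (0.51 log units; beyond the scatter) both beyond the scatter, so the high numbers at this place are not confined to dimethylamino: among these four compounds, methylsulfonyl and dimethylamino fall together, apart from chloro and ethoxy. Nothing available explains why these groups divide in this way.

The compounds shown leave open where a carboxylic acid, a primary amine or a longer alkoxy chain would fall at this place. They also leave open whether these four groups would divide the same way on another carbon of the ring.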